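Aryl variation at the amine-bound chain carbon: compound 4

The compounds below may be only part of what the source reports. "The series", "measured", "known", "first", "only" and "open" are said of these compounds alone.

Measured so far:
compound 1 `CC(C)(C)c1ccc(CNCCCNS(=O)(=O)c2cc(C(F)(F)F)cc(C(F)(F)F)c2)cc1` gives 2500 nM
compound 2 `COc1ccc(CNCCCNS(=O)(=O)c2cc(C(F)(F)F)cc(C(F)(F)F)c2)cc1OC` gives 18000 nM
compound 3 `O=S(=O)(NCCCNCc1cccc2ccccc12)c1cc(C(F)(F)F)cc(C(F)(F)F)c1` gives 2700 nM

In a functional assay on PANC-1 cells (Homo sapiens) for inhibition, read by MTT assay, with a stated time of 72 h (on this read-out higher numbers stand for weaker inhibition of growth and lower numbers for stronger inhibition of growth), compound 3 stands second highest of three numbers: the step of a 1.1-fold higher number from compound 1 to compound 3 (0.03 log units; within the scatter) is within the scatter, while a 6.7-fold lower number from compound 2 to compound 3 (0.82 log units; beyond the scatter) is a modest drop. Compound 4 `O=S(=O)(NCCCNCc1cccc(Cl)c1)c1cc(C(F)(F)F)cc(C(F)(F)F)c1` differs from compound 3 by 3-chlorophenyl in place of naphthalen-1-yl on a saturated chain carbon bound to an amine nitrogen. For the measured compounds named here, no measured step brings in 3-chlorophenyl. The steps of a 7.2-fold higher number from compound 1 to compound 2 (0.86 log units; beyond the scatter) and a 6.7-fold lower number from compound 2 to compound 3 (0.82 log units; beyond the scatter) show that the group at this position can shift the number modestly, whereas a 1.1-fold higher number from compound 1 to compound 3 (0.03 log units; within the scatter) shows two such groups giving the same number. A small rise is expected, within or just beyond the scatter, as a 1.5-fold higher number from compound 3 to compound 4 (0.17 log units; within the scatter). Compound 4 is estimated at 4000 nM, with a range from 1500 nM to 12000 nM.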

Compound 4, concentration for 50% growth inhibition: 12000 nM
Compound 4: middle estimate off by 3.0-fold (0.48 log units), on the low side; measured number inside the range.
By their numbers in this assay, from the lowest: compounds 1 and 3 (each within the scatter of the next); then compounds 4 and 2 (each within the scatter of the next).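

In this assay, 3-chlorophenyl does not hold the level of the larger aryl groups at this position (a 4.4-fold higher number from compound 3 to compound 4 (0.65 log units; beyond the scatter); a 4.8-fold higher number from compound 1 to compound 4 (0.68 log units; beyond the scatter)). It instead stays level with 3,4-dimethoxyphenyl (a 1.5-fold lower number from compound 2 to compound 4 (0.18 log units; within the scatter)), so the four aryl groups now fall into two pairs. No measurement available here accounts for this split.

From the compounds shown here alone, how a plain phenyl or a pyridine ring would fall at this carbon remains open. Also open, going by these compounds, is whether the two pairs would persist with a longer chain in place of the present one.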